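This account rests on a few compounds, and the source may have more. Where it says the series, first, only, none or still open, it means among the compounds named here.

Compound 1, `CCOC(=O)c1c(C)noc1OCC(=O)[C@H](CC(=O)O)NC(=O)[C@@H](NC(=O)COc1cccc2ccccc12)C(C)C`. In a functional assay on Jurkat cells (Homo sapiens) for inhibition (a lower number here means a stronger inhibitor, a higher number a weaker inhibitor), compound 1 gives > 200000 nM, which is a limit of the assay rather than a number.

Compound 2, `CC(C)[C@H](NC(=O)COc1cccc2ccccc12)C(=O)N[C@@H](CC(=O)O)C(=O)CSc1nc2ccccc2o1`. In this assay compound 2 gives > 200000 nM, again a limit and not a number.

Compound 2 therefore stands at the same limit as compound 1, and the change from compound 1 to compound 2 gives a step that the two limits leave unreadable from compound 1 to compound 2. For the measured compounds named here, the only evidence on the measured compounds is the limit of > 200000 nM in this assay, at which 2 of the 2 values shown sit, so no step of readable size exists here.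

Compound 3, `Cc1cc(C)nc(SCC(=O)[C@H](CC(=O)O)NC(=O)[C@@H](NC(=O)COc2cccc3ccccc23)C(C)C)n1`, has not been measured. It differs from compound 2 by 4,6-dimethylpyrimidin-2-yl in place of 1,3-benzoxazol-2-yl on a sulfur. Going by the values given here, the one measured step, from compound 1 to compound 2, bears on the same place in the molecule and was unreadable, so nothing supports an expectation of a step in either direction beyond the scatter in this assay; the expected step is a step that the limit leaves unreadable from compound 2 to compound 3, and it most likely also ends at a limit. Compound 3 is estimated to give 300000 nM, with a range from 50000 nM to 2000000 nM.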

Compound 3, half-maximal inhibitory concentration: > 200000 nM
Compound 3 gave a limit, no number (the forecaster's own chance of this, stated with the estimate: 80%); the middle value does not contradict the limit.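

Compound 3, like compound 1 and compound 2, stands at a limit of the assay and not at a number, so no step among these three compounds can be read: the limit of > 200000 nM in this assay, at which 3 of the 3 values shown sit.

What the compounds shown leave open is whether any group on the sulfur or in its place alters inhibition in this assay, since none of them gives a readable value.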